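Cyclohexyl replaces an aromatic ring on the side chain

The compounds below may be only part of what the source reports. "The series", "measured", "known", "first", "only" and "open" are said of these compounds alone.

compound 1 `Oc1ccc(/C=C/C[C@H]2C[C@@H]([C@@H](O)c3ccccc3)CO[C@@H]2c2ccccc2)cc1` gives 7380 nM
compound 2 `COc1ccc(/C=C/C[C@H]2C[C@@H]([C@@H](O)c3ccccc3)CO[C@@H]2c2ccccc2)cc1` gives 9010 nM
compound 3 `Cc1ccc(/C=C/C[C@H]2C[C@@H]([C@@H](O)c3ccccc3)CO[C@@H]2c2ccccc2)cc1C` gives 9880 nM

All three were tested in a functional assay on HL-60 cells (Homo sapiens) for cytotoxicity, read by WST assay, with a stated time of 48 h (on this read-out lower numbers stand for stronger inhibition and higher numbers for weaker inhibition), and differ only in the group on a double-bonded chain carbon bound to a double-bonded chain carbon. Compound 3 stands level with the other two: the steps of a 1.3-fold higher number from compound 1 to compound 3 (0.13 log units; within the scatter) and a 1.1-fold higher number from compound 2 to compound 3 (0.04 log units; within the scatter) are both within the scatter, and so is the step of a 1.2-fold higher number from compound 1 to compound 2 (0.09 log units; within the scatter) among the remaining pair.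

Compound 4 `O[C@@H](c1ccccc1)[C@H]1CO[C@H](c2ccccc2)[C@@H](C/C=C/C2CCCCC2)C1` differs from compound 3 as follows: cyclohexyl in place of 3,4-dimethylphenyl on a double-bonded chain carbon bound to a double-bonded chain carbon so cyclohexyl, a non-aromatic ring of carbon only, takes the place of 3,4-dimethylphenyl. Among the measured compounds shown here, no measured compound carries a non-aromatic ring at this place, so the three values guide the expectation only loosely. The swaps measured here all stayed small, so no step beyond the scatter is expected in this assay in either direction. The estimated step is a 1.1-fold lower number from compound 3 to compound 4 (0.04 log units; within the scatter) and its uncertainty is wide. For compound 4 the estimated value is 9000 nM with an expected range from 4000 nM to 20000 nM as the likely span.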

Compound 4, half-maximal inhibitory concentration: 6260 nM
Compound 4: middle estimate off by 1.4-fold (0.16 log units), on the high side; measured number inside the range.
By their numbers in this assay, from the lowest: compounds 4, 1, 2 and 3 (each within the scatter of the next).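

Replacing the aromatic ring with cyclohexyl leaves the number level with all three earlier compounds in this assay (the steps are a 1.6-fold lower number from compound 3 to compound 4 (0.20 log units; within the scatter) and a 1.4-fold lower number from compound 2 to compound 4 (0.16 log units; within the scatter) and a 1.2-fold lower number from compound 1 to compound 4 (0.07 log units; within the scatter)). The earlier compounds shown here changed only the groups carried on an aromatic ring, whereas compound 4 shows that a value in this range does not depend on the ring at this place being aromatic. Nothing available explains why this change makes so little difference.

As far as these compounds go, whether any group at this place can move the number beyond the scatter remains open. An amine, a carboxylic acid or a longer carbon chain in place of the ring could test this, and so could a cyclopentyl ring.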